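A Chlorine Swap on a Compound Stuck at the Limit

The source may report more compounds than this note shows. Statements on the series, on what has been measured and on what is new or still open speak of the compounds shown alone.

Measured in a functional assay on MDA-MB-231 cells (Homo sapiens) for cytotoxicity, read by MTT assay, with a stated time of 24 h; a higher number here means a weaker inhibitor, a lower number a stronger inhibitor:
- Compound 1 `COc1ccc(/C=C2\CN(C(=S)SCc3cn(Cc4ccccc4F)nn3)C/C(=C\c3ccc(OC)cc3)C2=O)cc1`: > 100000 nM, a limit and not a number
- Compound 2 `COc1ccc(/C=C2\CN(C(=S)SCc3cn(Cc4ccc(F)cc4)nn3)C/C(=C\c3ccc(OC)cc3)C2=O)cc1`: > 100000 nM, a limit and not a number

Compound 2 has no exact value in this assay, only its limit of > 100000 nM. It shares this position with compound 1, as the limit of > 100000 nM in this assay, at which 2 of the 2 values shown sit, shows.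

Compound 3 `COc1ccc(/C=C2\CN(C(=S)SCc3cn(Cc4cccc(Cl)c4)nn3)C/C(=C\c3ccc(OC)cc3)C2=O)cc1` changes one group of compound 2: 3-chlorophenyl in place of 4-fluorophenyl on a saturated chain carbon bound to an aromatic nitrogen. Put simply, 3-chlorophenyl takes the place of 4-fluorophenyl on a saturated chain carbon bound to an aromatic nitrogen, so 4-fluorobenzyl becomes 3-chlorobenzyl.

Within the data shown here, the only measured step that bears on this is a step that the two limits leave unreadable from compound 1 to compound 2, which changes the group at the same place. It has no readable size, so it offers no measured effect to carry forward. With no readable step to go on, the most likely result is that compound 3 also reaches the limit, although a measurable value cannot be ruled out.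

The expected step is a step that the limit leaves unreadable from compound 2 to compound 3, and it has no firm direction. For compound 3, the estimated value is 120000 nM, with an expected range of 40000 nM to 300000 nM.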

Compound 3, half-maximal inhibitory concentration: 32000 nM
Estimate against measurement, compound 3: 3.8-fold (0.57 log units) above, and the stated range ends above it.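

Changing the group on a saturated chain carbon bound to an aromatic nitrogen can bring a compound in this series off the limit in this assay. Among these compounds, replacing a fluorophenyl with 3-chlorophenyl gives an at least 3.1-fold lower number from compound 2 to compound 3 (0.49 log units; beyond the scatter) and, starting from the other fluorinated compound, an at least 3.1-fold lower number from compound 1 to compound 3 (0.49 log units; beyond the scatter); these are the first readable steps at this place, as the step between the two fluorinated compounds cannot be read. Both sizes are only minimums because one end of each step is a limit and not a number: the limit of > 100000 nM in this assay, at which 2 of the 3 values shown sit.

The compounds shown do not separate the effect of chlorine from that of its place on the ring, since 3-fluorophenyl and 4-chlorophenyl, each of which would change only one of the two, are not among them. Going by these compounds, whether 3-methoxyphenyl, or a longer chain in place of the ring, would lower the number further also stays open.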